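This account rests on a few compounds, and the source may have more. Where it says the series, first, only, none or still open, it means among the compounds named here.

Compound 1 `Nc1cc(N)c2nc(-c3ccccc3)c(Oc3ccc(Cl)c(Cl)c3)nc2c1` was tested in a functional assay on UO-31 cells (Homo sapiens) for inhibition, read by sulforhodamine B assay, with a stated time of 48 h (on this read-out lower numbers stand for higher toxicity in this test and higher numbers for lower toxicity in this test), where the reading for it is a limit of the assay and not a number, given as < 100000 nM. Two further compounds built on the same core stand beside it. Compound 2 `CCOC(=O)[C@H](CCC(=O)O)NC(=O)c1ccc(CNc2nc3cc(N)cc(N)c3nc2-c2ccccc2)cc1` gives in this assay a limit as well, < 100000 nM. Compound 3 `CCOC(=O)[C@H](CCC(=O)O)NC(=O)c1ccc(Sc2nc3cc(N)cc(N)c3nc2-c2ccccc2)cc1` likewise gives in this assay only a limit, < 100000 nM. Going by the values given here, the picture so far is summed up by the observation that (the limit of < 100000 nM in this assay, at which 3 of the 3 values shown sit); no step between any two of these measured compounds can be read from such limits, so compound 1 stands at the limit and nowhere more precise.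

Compound 4 `Nc1cc(N)c2nc(-c3ccccc3)c(Oc3ccc(F)cc3)nc2c1` differs from compound 1 in a single place: 4-fluorophenyl in place of 3,4-dichlorophenyl on an oxygen on an aromatic ring. Among the compounds with values here, since none of the measured compounds gives a number in this assay, there is no measured step of a like kind to lean on, and the only footing is that compound 1 sits at the limit. The expectation is therefore that compound 4 shows no step beyond the scatter, so that the step from compound 1 to compound 4 is estimated as a number no lower from compound 1 to compound 4 (the limit leaves the size open). In this assay compound 4 is expected to give 100000 nM, with a range from 30000 nM to 300000 nM, most probably again as a limit rather than a number.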

Compound 4, concentration lethal to 50% of the cells: < 100000 nM
Compound 4 gave a limit, no number; the forecaster's own chance of this, stated with the estimate: 75%; the middle value sits exactly at the limit.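

Going by these compounds alone, compound 1 and compound 4 each give only a limit of the assay and not a number, so no step between them can be read in this assay: the limit of < 100000 nM in this assay, at which 4 of the 4 values shown sit. The compounds shown leave open what number any of them would give, and whether any change on the shared core alters the read-out at all.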